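This account rests on a few compounds, and the source may have more. Where it says the series, first, only, none or still open, it means among the compounds named here.

Working notes on the series. In an ADME assay on MT4 cells (Homo sapiens) for cytotoxicity, read by MTT assay, with a stated time of 96 h (on this read-out higher numbers stand for lower toxicity in this test and lower numbers for higher toxicity in this test), compound 1 `NS(=O)(=O)c1ccc(N2N=C(c3ccc(OCc4ccccc4)cc3)CC2c2ccccc2)cc1` reads > 100000 nM, which is a limit of the assay. Compound 2 `NS(=O)(=O)c1ccc(N2N=C(c3ccc(OCc4ccccc4)cc3)CC2c2ccccc2Cl)cc1` gives 26000 nM and compound 3 `NS(=O)(=O)c1ccc(N2N=C(c3ccc(OCc4ccccc4)cc3)CC2c2ccccc2F)cc1` gives 39000 nM, so that a 1.5-fold higher number from compound 2 to compound 3 (0.18 log units; within the scatter) leaves these two within the scatter of each other. The next change leads to compound 4 `NS(=O)(=O)c1ccc(N2N=C(c3ccc(Oc4ccccc4)cc3)CC2c2ccccc2Cl)cc1`: phenyl in place of benzyl on an oxygen on an aromatic ring. Within the data shown here, no measured step touches that place. The halogen steps an at least 3.8-fold lower number from compound 1 to compound 2 (0.58 log units; beyond the scatter) and an at least 2.5-fold lower number from compound 1 to compound 3 (0.40 log units; beyond the scatter) lie beyond the scatter but concern another aromatic carbon, so they give only a loose guide to size. The expected change is a 1.2-fold higher number from compound 2 to compound 4 (0.06 log units; within the scatter), with no step beyond the scatter and no firm direction. For compound 4 the estimate is 30000 nM, with an expected range of 10000 nM to 90000 nM.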

Compound 4, half-maximal cytotoxic concentration: 40000 nM
The estimate for compound 4 lay 1.3-fold (0.12 log units) below the measured number; the range from low to high includes it.
By their numbers in this assay, from the lowest: compounds 2, 3 and 4 (each within the scatter of the next). At a limit, above all of these: compound 1.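

In this assay, among these compounds, a 1.5-fold higher number from compound 2 to compound 4 (0.19 log units; within the scatter) is the first reading at the place on an oxygen on an aromatic ring. With the chloro compound as base, phenyl in place of benzyl there shows no change that can be told from the scatter. Compound 2 and compound 4 both read as numbers clear of the one ceiling in the series, which belongs to compound 1: the limit of > 100000 nM in this assay, at which 1 of the 4 values shown sits.

From the compounds shown here alone, whether the same exchange holds on the compound 1 background stays open. So does how an amine or a longer alkyl chain on that oxygen would read.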